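The source may report more compounds than this note shows. Statements on the series, on what has been measured and on what is new or still open speak of the compounds shown alone.

Within the data shown here, in a functional assay on HepG2 cells (Homo sapiens) for inhibition, read by MTT assay, with a stated time of 48 h (a lower number here means a stronger inhibitor, a higher number a weaker inhibitor), compound 3 `COc1cc(C(=O)/C=C/c2ccc(O)c(O)c2)cc(OC)c1OC` gives 14900 nM, the only actual number among the measured compounds. Compound 1 `COc1cc(/C=C/C(=O)c2cc(OC)c(OC)c(OC)c2)ccc1O` gives a limit and not a number, > 100000 nM. Compound 2 `COc1ccc(/C=C/C(=O)c2cc(OC)c(OC)c(OC)c2)c(OC)c1` also gives a limit, > 100000 nM. The measured set therefore offers one number and (the limit of > 100000 nM in this assay, at which 2 of the 3 values shown sit).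

Compound 4 `COc1cc(C(=O)/C=C/c2cccc(C=O)c2)cc(OC)c1OC` carries 3-formylphenyl in place of 3,4-dihydroxyphenyl on a double-bonded chain carbon bound to a double-bonded chain carbon. Among the measured compounds shown here, one measured step bears on this change. Putting hydrogen in place of methyl on an oxygen on an aromatic ring gave an at least 6.7-fold lower number from compound 1 to compound 3 (0.82 log units; beyond the scatter). That step is a limited guide, since it alters only one oxygen and its size is known only as a minimum. Of the three measured compounds, only compound 3 carries 3,4-dihydroxyphenyl, and only compound 3 gives a number. For the measured compounds named here, compound 4 loses that group entirely, and no measured compound carries 3-formylphenyl.

A move towards weaker inhibition, beyond the scatter, is therefore expected, and the assay may report only a limit. The expected change is a 3.4-fold higher number from compound 3 to compound 4 (0.53 log units; beyond the scatter). For compound 4 the estimate is 50000 nM, with an expected range from 15000 nM to 150000 nM.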

Compound 4, half-maximal inhibitory concentration: > 100000 nM
Compound 4: a limit, no number; the forecaster's own chance of this, stated with the estimate: 40%; at least 2.0-fold (0.30 log units) between middle value and limit.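

In this assay, exchanging the group at this position, on a double-bonded chain carbon bound to a double-bonded chain carbon, gives an at least 6.7-fold higher number from compound 3 to compound 4 (0.82 log units; beyond the scatter), and that size is only a minimum. The earlier step altered a single oxygen, whereas here 3,4-dihydroxyphenyl is replaced as a whole by 3-formylphenyl, a group with the same count of heavy atoms and 0 hydrogen-bond donors against 2, and no actual number remains. Compound 3 is still the only compound with a measured number, and compound 4 now joins compound 1 and compound 2 at the assay's limit: the limit of > 100000 nM in this assay, at which 3 of the 4 values shown sit.

The compounds shown do not separate the loss of the two hydroxyl groups from the arrival of the formyl group, and compound 1, compound 2 and compound 4 cannot be ranked against one another, as each gives only a limit. On these data alone, it also remains open how 3-hydroxyphenyl or 4-hydroxyphenyl would behave at this position, or whether a carboxylic acid or an amine in place of the formyl group would bring back a measurable value.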